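Pyridinyl to hydroxyphenyl on a hydrazone carbon

This account rests on a few compounds, and the source may have more. Where it says the series, first, only, none or still open, it means among the compounds named here.

Compound 2 `Cc1c(C(=O)N/N=C\c2ccncc2)oc2cccc(O)c12` is known in a functional assay on PC-3 cells (Homo sapiens) for inhibition (a higher number here means a weaker inhibitor, a lower number a stronger inhibitor), only as a limit, returning >= 40000 nM, so no number is available for it. Compound 1 `Cc1c(C(=O)N/N=C\c2ccc(O)c(O)c2O)oc2cccc(O)c12` likewise gives a limit in this assay, >= 40000 nM. Among the measured compounds shown here, compound 3 `Cc1c(C(=O)N/N=C\c2cc(Cl)cc(Cl)c2O)oc2cccc(O)c12` is the one member of the set with a measured number, 9590 nM in this assay. Compound 2 therefore stands with compound 1 at the limit of >= 40000 nM in this assay, at which 2 of the 3 values shown sit, while compound 3 alone lies below that limit.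

Compound 4 `Cc1c(C(=O)N/N=C\c2ccccc2O)oc2cccc(O)c12` has not yet been measured. It differs from compound 2 in one place: 2-hydroxyphenyl in place of pyridin-4-yl on a carbon with a double bond to nitrogen. Because compound 2 is known only as a limit, the size of any step from it cannot be judged; the account expects a move toward stronger inhibition, an at least 1.6-fold lower number from compound 2 to compound 4 (0.20 log units; that floor lies within the scatter), though a further limit reading would not be surprising. Compound 4 is expected to give about 25000 nM in this assay, with a range from 8000 nM to 60000 nM.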

Compound 4, half-maximal inhibitory concentration: 8350 nM
For compound 4 the middle estimate is 3.0-fold (0.48 log units) above the measured one, within the range that was stated.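

In this assay, among the compounds shown here, the group on the carbon with a double bond to nitrogen matters: 2-hydroxyphenyl in place of pyridin-4-yl gives an at least 4.7-fold lower number from compound 2 to compound 4 (0.68 log units; beyond the scatter), the first step in this set that can be read. The change removes the ring nitrogen and adds a hydrogen-bond donor, and this single pair cannot separate those two differences. Compound 2 is known only as a limit, so the step gives a minimum and not a full size: the limit of >= 40000 nM in this assay, at which 2 of the 4 values shown sit.

The compounds shown leave open how a plain phenyl or a 2-methoxyphenyl group would read on this carbon, and so whether the hydroxyl or the loss of the ring nitrogen carries the step. They also leave open how 3-hydroxyphenyl or 4-hydroxyphenyl would compare with 2-hydroxyphenyl.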